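From Methyl to Fluoro at Compound 2

The source may hold more compounds than are shown below. What is called first, only, known or untested is meant among the compounds shown, and "the series" means these compounds.

Compound 1 `O=C(Nc1cccc(-c2ccccc2C(F)(F)F)c1)C(Cl)Cl` gives 7550 nM
Compound 2 `Cc1ccccc1-c1cccc(NC(=O)C(Cl)Cl)c1` gives 31600 nM

In a functional assay on NCI-H460 cells (Homo sapiens) for cytotoxicity, read by MTT assay, with a stated time of 68 h (a lower number here means a stronger inhibitor, a higher number a weaker inhibitor), compound 2 stands highest of the two at 31600 nM and is the weaker inhibitor of the pair. Compound 3 `O=C(Nc1cccc(-c2ccccc2F)c1)C(Cl)Cl` has fluoro in place of methyl on an aromatic carbon, ortho to a large group (fluoro in place of methyl on an aromatic carbon). For the measured compounds named here, the one measured step that bears on this change, modest in size, puts that methyl in place of trifluoromethyl (a 4.2-fold higher number from compound 1 to compound 2 (0.62 log units; beyond the scatter)). Going by the values given here, no fluoro compound has been measured, so only a small step toward a lower number is expected, possibly none beyond the scatter (a 1.4-fold lower number from compound 2 to compound 3 (0.16 log units; within the scatter)). In this assay compound 3 is expected at 22000 nM within an estimated range from 9000 nM to 50000 nM as the likely outcome.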

Compound 3, half-maximal inhibitory concentration: 26800 nM
For compound 3 the middle estimate is 1.2-fold (0.09 log units) below the measured one, within the range that was stated.
By their numbers in this assay, from the lowest: compound 1; then compounds 3 and 2 (each within the scatter of the next).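

In this assay, fluoro and methyl on this aromatic carbon, ortho to a large group, cannot be told apart (a 1.2-fold lower number from compound 2 to compound 3 (0.07 log units; within the scatter)). Only trifluoromethyl stands apart among these three groups, now against fluoro as well as methyl (a 3.5-fold higher number from compound 1 to compound 3 (0.55 log units; beyond the scatter)). No measurement at hand accounts for this difference.

The compounds shown leave open whether chloro, methoxy or an amine on this carbon would group with trifluoromethyl or with methyl and fluoro. They also leave open whether trifluoromethyl would keep its place with a different group in place of the dichloroacetyl amide.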